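Cytotoxicity of a Pyridine Series: From Fluorine to Chlorine

The source may report more compounds than this note shows. Statements on the series, on what has been measured and on what is new or still open speak of the compounds shown alone.

This small set of compounds shares one core and differs only in the aryl group attached to it. Compound 1 `COc1nc(-c2cccc(Cl)c2)ccc1[C@@H](c1ccccc1)[C@@](O)(CCN(C)C)c1cccc2ccccc12` has no number in a toxicity assay on HeLa cells (Homo sapiens) for cytotoxicity; on this read-out lower numbers stand for higher toxicity in this test and higher numbers for lower toxicity in this test: for compound 1 the entry reads "nd" (no result reported). Compound 3 `COc1nc(-c2ccccc2F)ccc1[C@@H](c1ccccc1)[C@@](O)(CCN(C)C)c1cccc2ccccc12` likewise has no number in this assay: for compound 3 the entry reads "nd" (no result reported). Among the measured compounds shown here, compound 2 `COc1nc(-c2cccc(F)c2)ccc1[C@@H](c1ccccc1)[C@@](O)(CCN(C)C)c1cccc2ccccc12` is therefore the only member with a result: in this assay compound 2 gives 62.8 ug/mL, so it is the sole reference point, with no comparison to other measured compounds possible.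

Compound 4 `COc1nc(-c2ccccc2Cl)ccc1[C@@H](c1ccccc1)[C@@](O)(CCN(C)C)c1cccc2ccccc12` is the next member to be tested. Compared with compound 2, the difference is 2-chlorophenyl in place of 3-fluorophenyl on an aromatic carbon. For the measured compounds named here, with no measured pair to show how such a swap moves the read-out, the expectation rests on the single number from compound 2 and on the fact that the change is small relative to the whole molecule. No step beyond the usual scatter is expected, and the step of a 1.1-fold lower number from compound 2 to compound 4 (0.06 log units; within the scatter) is the estimated outcome. Compound 4 is expected to give 55 ug/mL, with a likely range from 25 ug/mL to 120 ug/mL.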

Compound 4, half-maximal cytotoxic concentration: > 64 ug/mL
Compound 4 gave a limit, no number; the forecaster's own chance of this, stated with the estimate: 10%; at least 1.1-fold (0.06 log units) between middle value and limit.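

In this assay compound 4 gives a limit rather than a number: the limit of > 64 ug/mL in this assay, at which 1 of the 4 values shown sits. Going by these compounds, the comparison reads as an at least 1.0-fold higher number from compound 2 to compound 4 (0.00 log units; that floor lies within the scatter), so the true size of the step is unknown, and it could be small or much larger. Among the compounds shown here, still, this is the first comparison at the aromatic carbon next to the ring nitrogen, and it shows that 2-chlorophenyl in place of 3-fluorophenyl gives no sign of a lower number, which would mean higher toxicity in this test.

Steps involving compound 1 and compound 3 cannot be read, and because compound 4 changes both the halogen and its place on the phenyl ring, the two changes cannot be separated. On these data alone, how a phenyl ring carrying an amine or a carboxylic acid would behave at this position also remains open.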